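Amine variation on the shared core

The compounds below may be only part of what the source reports. "The series", "measured", "known", "first", "only" and "open" are said of these compounds alone.

Two members of the series are measured so far in a functional assay on ECa-109 cells (Homo sapiens) for cytotoxicity, read by MTT assay, with a stated time of 72 h; a lower number here means a stronger inhibitor, a higher number a weaker inhibitor. Compound 1 `Cc1cc(NC(C)C)nc(SCc2nc3ccccc3[nH]2)n1` carries an isopropylamino group; in this assay compound 1 gives only the assay limit > 100000 nM. Compound 2 `Cc1cc(N2CCCCC2)nc(SCc2nc3ccccc3[nH]2)n1` carries piperidin-1-yl in its place; in this assay compound 2 likewise gives only the limit > 100000 nM. The step that the two limits leave unreadable from compound 1 to compound 2 is therefore unreadable, as the limit of > 100000 nM in this assay, at which 2 of the 2 values shown sit, records. Compound 2 stands at that limit, as does every value shown.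

Compound 3 `Cc1cc(NCCO)nc(SCc2nc3ccccc3[nH]2)n1` differs from compound 2 by (2-hydroxyethyl)amino in place of piperidin-1-yl on an aromatic carbon. For the measured compounds named here, the only measured step at the same place, from compound 1 to compound 2, gives no readable size, so no direction can be taken from it. Compound 3 is therefore expected to remain close to the limit, with the estimated step that the limit leaves unreadable from compound 2 to compound 3 in this assay. Compound 3 is estimated at 150000 nM in this assay, within 30000 nM to 600000 nM.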

Compound 3, half-maximal inhibitory concentration: > 100000 nM
Compound 3 gave a limit, no number; the forecaster's own chance of this, stated with the estimate: 80%; the middle value lies beyond the limit too.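

No new step can be read among compound 1, compound 2 and compound 3 in this assay, because each gives only a limit and no number: the limit of > 100000 nM in this assay, at which 3 of the 3 values shown sit. The compounds shown leave open whether any amine on the shared core gives a readable value.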